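The source may hold more compounds than are shown below. What is called first, only, known or untested is meant among the compounds shown, and "the series" means these compounds.

Measured compounds:

Compound 1, `Cn1cc(CNS(=O)(=O)c2ccccc2Nc2cc(-c3ccc4ccn(C)c4c3)c3nccnc3c2)cn1`: in an ADME assay on microsomes from liver (Mus musculus, strain CD-1) for metabolic stability, read by LC-MS, tested at 2 uM (a lower number here means that the compound disappears faster, a higher number that the compound lasts longer), compound 1 gives 0.267 h.
Compound 2, `Cn1ccc2ccc(-c3cc(Nc4ccccc4S(=O)(=O)NCC4CCOCC4)cc4nccnc34)cc21`: in this assay compound 2 gives 0.3 h.
Compound 3, `CN1CCC(NC(=O)c2ccncc2Nc2cc(-c3ccc4ccn(C)c4c3)c3nccnc3c2)CC1=O`: in this assay compound 3 gives 0.717 h.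

Compound 3 stands highest of the three, and its gaps to compound 1 and to compound 2 both lie beyond the usual scatter of such measurements, so it is the longest-lasting of the set. Among the measured compounds shown here, the only measured step between compounds that differ in one place is a 1.1-fold higher number from compound 1 to compound 2 (0.05 log units; within the scatter), a change that sits at another part of the molecule and says nothing directly about the site now altered.

Compound 4, `CN1CCC(N(C)C(=O)c2ccncc2Nc2cc(-c3ccc4ccn(C)c4c3)c3nccnc3c2)C1`, differs from compound 3 in one place: methyl(1-methylpyrrolidin-3-yl)amino in place of (1-methyl-2-oxopiperidin-4-yl)amino on a carbonyl carbon. For the measured compounds named here, no measured pair shows what this kind of exchange does in this assay. With nothing to point either way, the expected step from compound 3 to compound 4 is a 1.4-fold lower number from compound 3 to compound 4 (0.16 log units; within the scatter), which is not beyond the scatter, though the uncertainty around it is wide. Compound 4 is therefore estimated at 0.5 h, with a likely range from 0.2 h to 1.2 h.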

Compound 4, half-life: > 1 h
Compound 4 ended at the assay's limit; the forecaster's own chance of this, stated with the estimate: 5%; middle value at least 2.0-fold (0.30 log units) from the limit.
By their numbers in this assay, from the lowest: compounds 1 and 2 (each within the scatter of the next); then compound 3. At a limit, above all of these: compound 4.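

Compound 4 sits at a limit of this assay, so its entry is not an exact number: the limit of > 1 h in this assay, at which 1 of the 4 values shown sits.

Placing methyl(1-methylpyrrolidin-3-yl)amino in place of (1-methyl-2-oxopiperidin-4-yl)amino on the carbonyl carbon gives an at least 1.3-fold higher number from compound 3 to compound 4 (0.14 log units; that floor lies within the scatter). Among the compounds shown here, this is the first reading at this position, and it shows that this exchange brings no measured drop in half-life, although the true size of the step remains unknown.

The exchange alters the ring size, the ring carbonyl and the hydrogen-bond donor count all at once, so the compounds shown leave open which of these differences matters in this assay. A simpler dimethylamino group or a 1-methylpiperidin-4-yl(methyl)amino group on the same carbonyl carbon could help to separate these differences.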